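From 2-Methoxyphenyl to 4-Fluorophenyl in a Growth Test

This account rests on a few compounds, and the source may have more. Where it says the series, first, only, none or still open, it means among the compounds named here.

Three related compounds have been tested so far in a functional assay on PC-3 cells (Homo sapiens) for inhibition, with a stated time of 48 h, tested at 50 uM; a lower number here means less inhibition of growth, a higher number more inhibition of growth at the concentration tested. Compound 1 `C=C[C@@](C)(/C=C/c1ccc(OC(=O)CCCCC)cc1)CCC=C(C)C` gives 28%, compound 2 `CC[C@](C)(CCCC(C)C)CCc1ccc(O)cc1` gives 40%, and compound 3 `COc1ccccc1/C=C/[C@@](C)(/C=C/c1ccc(O)cc1)CCC=C(C)C` gives 46%. Compound 3 therefore sits level with compound 2 within the usual scatter, and above compound 1 by more than the scatter. Compound 4 `CC(C)=CCC[C@](C)(/C=C/c1ccc(O)cc1)/C=C/c1ccc(F)cc1` is still unmeasured. It differs from compound 3 in one place, with 4-fluorophenyl in place of 2-methoxyphenyl on a double-bonded chain carbon bound to a double-bonded chain carbon. For the measured compounds named here, no measured pair shows what such a swap does, so the data offer no guide to its size. The expected step of a number 4 percentage points lower from compound 3 to compound 4 (within the scatter) is small, slightly downward and within the scatter. Compound 4 is estimated at 42%, with an expected range of 25% to 60%.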

Compound 4, percent growth inhibition at one concentration: 33%
Beside the measured number, compound 4's estimate is 9 percentage points above it; measured number inside the range.
By their numbers in this assay, from the lowest: compounds 1, 4, 2 and 3 (each within the scatter of the next, the first and the last beyond it).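

For the compounds shown here, this is the first pair differing in only one place, and it shows that the group carried at this position can change growth inhibition in this assay: replacing 2-methoxyphenyl with 4-fluorophenyl gives a number 13 percentage points lower from compound 3 to compound 4 (beyond the scatter) at this position. No measurement at hand accounts for this step.

The compounds shown cannot separate the effect of removing the methoxy group from that of adding the fluorine. An unsubstituted phenyl or a 4-methoxyphenyl group at the same place would help to tell these two apart.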